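This account rests on a few compounds, and the source may have more. Where it says the series, first, only, none or still open, it means among the compounds named here.

Measured so far:
- compound 1, `Nc1ccccc1NC(=O)c1ccc(NC(=S)NCc2cncc(Br)c2)cc1`, 7500 nM
- compound 2, `Nc1ccccc1NC(=O)c1ccc(CNC(=O)c2cc3cnccc3[nH]2)cc1`, 1700 nM

Of the compounds shown here, two have been measured in a functional assay on HepG2 cells (Homo sapiens) for cytotoxicity, read by MTT assay, with a stated time of 72 h; a higher number here means a weaker inhibitor, a lower number a stronger inhibitor. Compound 1 has the higher of the two numbers, so on this pair it is the weaker inhibitor of cell growth; compound 2 gives a lower number, and the gap between them is beyond the usual scatter of repeated measurements. Compound 2 is built differently around the shared core and has no single change in common with compound 1, so its number serves only as a second point on the scale.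

Compound 3, `Nc1ccccc1NC(=O)c1ccc(NC(=S)NCc2ccccc2F)cc1`, has not been measured. It differs from compound 1 in one place: 2-fluorophenyl in place of 5-bromopyridin-3-yl on a saturated chain carbon bound to an amide-type nitrogen. The rest of the molecule, including the thiourea link and the shared core, stays the same. Among the measured compounds shown here, with no pair of measured compounds showing this kind of exchange, there is no measured step to lean on. The change is expected to give at most a small step in this assay, if any, slightly toward a lower number, a 1.5-fold lower number from compound 1 to compound 3 (0.18 log units; within the scatter). Compound 3 is therefore estimated at 5000 nM, with a likely range from 2000 nM to 15000 nM.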

Compound 3, half-maximal inhibitory concentration: 5400 nM
Estimate against measurement, compound 3: 1.1-fold (0.03 log units) below; low and high end bracket the measured number.
By their numbers in this assay, from the lowest: compound 2; then compounds 3 and 1 (each within the scatter of the next).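

In this assay, among the compounds shown here, exchanging 5-bromopyridin-3-yl for 2-fluorophenyl, on a saturated chain carbon bound to an amide-type nitrogen, gives a 1.4-fold lower number from compound 1 to compound 3 (0.14 log units; within the scatter) and provides the first measured step at this position. For this one pair, a carbon-only aromatic ring bearing fluorine can stand in place of a ring that contains a hetero atom and bears bromine, and the hydrogen-bond acceptor counted on the departing group disappears, without any change that can be told apart from the ordinary spread of repeated measurements. No measured evidence here bears on why the exchange leaves the reading within that spread.

This single exchange leaves open whether the position would respond to groups of a more different kind, such as a primary amine, a carboxylic acid or a longer alkyl chain in place of the aromatic ring. It also leaves open what plain phenyl would give at the same place, a comparison that would help separate the contribution of the fluorine from that of the carbon-only ring.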